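A few compounds are considered here, and "the series" means these few. Any claim that something is new, unique, unknown or untested is made for them only; others in the source may bear on it.

Within the data shown here, compound 2 `CCn1c(C(=O)Nc2cccc(C(F)(F)F)c2)ccc1C(CC)(CC)c1ccc(OCCC(O)(CC)CC)c(C)c1` is the only compound with a numbered result in a functional assay on PC-3 cells (Homo sapiens) for antiproliferative activity, read by MTT assay, with a stated time of 48 h; a higher number here means a weaker inhibitor, a lower number a stronger inhibitor: compound 2 gives 23800 nM. Compound 1 `C#CCCOC(=O)c1ccc(C(CC)(CC)c2ccc(OCCC(O)(CC)CC)c(C)c2)n1CC` reaches only a limit of the assay, > 50000 nM. Among the measured compounds shown here, the one measured step, an at least 2.1-fold lower number from compound 1 to compound 2 (0.32 log units; beyond the scatter), rests on that limit, (the limit of > 50000 nM in this assay, at which 1 of the 2 values shown sits), so its true size is open.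

Compound 3 `CCC(C)C(NC(=O)c1ccc(C(CC)(CC)c2ccc(OCCC(O)(CC)CC)c(C)c2)n1CC)C(=O)O` differs from compound 2 at the amide-type nitrogen: 1-carboxy-2-methylbutyl in place of 3-(trifluoromethyl)phenyl on an amide-type nitrogen. For the measured compounds named here, no measured step changes this part of the molecule in the same way, so the single step from compound 1 to compound 2 bears on it only loosely, showing that swapping the group on the carbonyl carbon can move this assay beyond the scatter. With a carboxylic acid entering, compound 3 is expected to be no stronger than compound 2, with a step of a 1.7-fold higher number from compound 2 to compound 3 (0.23 log units; within the scatter) of modest size toward a higher number. The estimate for compound 3 in this assay is 40000 nM, within 15000 nM to 100000 nM.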

Compound 3, half-maximal inhibitory concentration: 13800 nM
Compound 3: the middle estimate sits 2.9-fold (0.46 log units) above what was measured; the whole stated range lies above it.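

In this assay, the amide-type nitrogen carries 1-carboxy-2-methylbutyl or 3-(trifluoromethyl)phenyl with no difference that can be told from the scatter: a 1.7-fold lower number from compound 2 to compound 3 (0.24 log units; within the scatter). An open chain with a carboxylic acid and a group with an aromatic ring therefore read alike here, something a single numbered amide could not show. Set against the (but-3-yn-1-yl)oxy group of compound 1, this second amino group also gives a step beyond the scatter, an at least 3.6-fold lower number from compound 1 to compound 3 (0.55 log units; beyond the scatter), and its true size is open, as it rests on a limit of the assay: the limit of > 50000 nM in this assay, at which 1 of the 3 values shown sits.

Going by these compounds, whether the carboxylic acid or the branched chain matters in 1-carboxy-2-methylbutyl remains open, as does how a methyl ester or a primary amine would read on the same nitrogen. Whether compound 2 and compound 3 also read alike outside this assay is open too.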